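The compounds below may be only part of what the source reports. "The series", "measured", "known", "first", "only" and "open" are said of these compounds alone.

Measured compounds in a functional assay on U-251 cells (Homo sapiens) for inhibition; a higher number here means a weaker inhibitor of growth, a lower number a stronger inhibitor of growth:
Compound 1, `COc1cc(/C=C/C(=O)c2cccc(-n3cc(-c4ccccc4)[nH]c3=O)c2)ccc1O`, gives 2110 nM.
Compound 2, `O=C(/C=C/c1cccc(O)c1)c1cccc(-n2cc(-c3ccccc3)[nH]c2=O)c1`, gives 1610 nM.
Compound 3, `COc1cc(/C=C/C(=O)c2cccc(-n3cc(-c4ccccc4)[nH]c3=O)c2)cc(OC)c1OC`, gives 630 nM.

Among these three, compound 3 has the lowest number and is thus the strongest growth inhibitor of the set; its gaps to compound 2 and to compound 1 both lie beyond the scatter. Among the compounds with values here, the single step that can be traced between two measured compounds changes the ring on the double-bonded chain: a 1.3-fold lower number from compound 1 to compound 2 (0.12 log units; within the scatter), a difference that stays within the scatter.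

Compound 4, `COc1ccc(-c2cn(-c3cccc(C(=O)/C=C/c4cc(OC)c(OC)c(OC)c4)c3)c(=O)[nH]2)cc1`, keeps everything in compound 3 and alters only the phenyl on the core: methoxy in place of hydrogen on an aromatic carbon. Within the data shown here, none of the measured steps touches this phenyl. The change from compound 1 to compound 2, and the separation of compound 3 from compound 1 and compound 2, all concern the ring on the double-bonded chain. So there is no measured basis for a shift in this assay in either direction, and the expectation is a step that stays within the scatter. Compound 4 is therefore estimated at 630 nM, with a range from 250 nM to 1600 nM. The expected step is no change at the digits printed from compound 3 to compound 4 (within the scatter).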

Compound 4, concentration for 50% growth inhibition: 880 nM
Compound 4: the middle estimate sits 1.4-fold (0.15 log units) below what was measured; low and high end bracket the measured number.
By their numbers in this assay, from the lowest: compounds 3, 4, 2 and 1 (each within the scatter of the next, the first and the last beyond it).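

Within the data shown here, compound 4 is the first measured change on the phenyl attached to the shared core, as all earlier differences concerned the ring on the double-bonded chain. In this assay, going from phenyl to 4-methoxyphenyl gives a 1.4-fold higher number from compound 3 to compound 4 (0.15 log units; within the scatter) and so adds two heavy atoms and one hydrogen-bond acceptor, para to a large group, without a difference that can be told from the scatter of repeated measurements. Among these compounds, this single pair therefore shows that growth inhibition in these cells is kept with a methoxy at this position, at least when the ring on the chain is the one in compound 3, although no measurement here explains why the step is so small.

On these data alone, what remains open is whether this position would accept a group of another kind, such as an amine, a carboxylic acid or a longer alkoxy chain, or whether those groups would shift the number beyond the scatter. As far as these compounds go, it is also open whether methoxy would give a similar result at other places on this phenyl, or with the chain rings of compound 1 and compound 2.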